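The source may report more compounds than this note shows. Statements on the series, on what has been measured and on what is new or still open speak of the compounds shown alone.

Working notes on the series. In a functional assay on the whole organism (ileum) with Rattus norvegicus as the target (on this read-out higher numbers stand for larger maximal responses and lower numbers for smaller maximal responses), compound 1 `COc1ccccc1-c1nc2ccccc2[nH]1` gives 52.8% and compound 2 `CCOc1ccccc1-c1nc2ccccc2[nH]1` gives 50%. Within the data shown here, the one step measured so far, a number 2.8 percentage points lower from compound 1 to compound 2 (within the scatter), is a change of methyl in place of hydrogen on a saturated chain carbon bound to an oxygen on an aromatic ring. Compound 2 therefore stands within the scatter of compound 1; the two numbers cannot be told apart on this assay.

Compound 3 `CCCOc1ccccc1-c1nc2ccccc2[nH]1` differs from compound 2 by methyl in place of hydrogen on a saturated chain carbon, two bonds along the chain from an oxygen on an aromatic ring, which cut one bond further out reads ethoxy to propoxy. Among the measured compounds shown here, the only measured step that bears on it is the earlier chain lengthening, which was within the scatter. No step beyond the scatter is expected in this assay from compound 2 to compound 3, so the estimate is a number 1 percentage points lower from compound 2 to compound 3 (within the scatter). Compound 3 is expected to give about 49%, with a range from 36% to 62%.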

Compound 3, largest response reached (Emax), in percent of the reference or control that the assay uses: 80%
Compound 3: middle estimate off by 31 percentage points, on the low side; measured number above the stated range.
By their numbers in this assay, from the lowest: compounds 2 and 1 (each within the scatter of the next); then compound 3.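

The chain on this position is not silent in this assay: ethoxy to propoxy gives a step beyond the scatter (a number 30 percentage points higher from compound 2 to compound 3 (beyond the scatter)), while the methyl added one carbon nearer the oxygen gave no readable change (a number 2.8 percentage points lower from compound 1 to compound 2 (within the scatter)). The comparison with the shortest chain points the same way (a number 27.2 percentage points higher from compound 1 to compound 3 (beyond the scatter)), so among these three compounds the response separates only once the methyl sits on the saturated chain carbon two bonds along the chain from the oxygen on an aromatic ring. Nothing measured here accounts for this rise.

With three compounds, a single rise cannot be told apart from a continuing trend. As far as these compounds go, whether a butoxy or longer chain holds, extends or reverses it remains open, as does whether a branched isopropoxy group reaches the same response.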